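This account rests on a few compounds, and the source may have more. Where it says the series, first, only, none or still open, it means among the compounds named here.

Measured compounds:
- compound 1 `CC/C=C\COC1(c2ccc(Cl)cc2)SC=C(C)n2c1noc2=O` — 1310 nM
- compound 2 `CC/C=C\COC1(c2ccc(Br)cc2)SC=C(C)n2c1noc2=O` — 630 nM
- compound 3 `CC1=CS[C@@](OCC2CCCCC2)(c2ccc(Cl)cc2)c2noc(=O)n21` — 240 nM

In a functional assay (Cavia porcellus) with Rattus norvegicus as the target (on this read-out higher numbers stand for an effect only at larger amounts of compound and lower numbers for an effect already at smaller amounts), compound 1 gives 1310 nM, and compound 2 gives 630 nM. The two differ only by bromo in place of chloro on an aromatic carbon, and that single change gave a 2.1-fold lower number from compound 1 to compound 2 (0.32 log units; beyond the scatter). Compound 3, built on a different core, gives 240 nM in this assay and stands lowest of the three; the difference between its core and the core of compound 1 is not broken down here.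

Compound 4 `CC1=CS[C@@](OCC2CCCCC2)(c2ccc(Br)cc2)c2noc(=O)n21` has not yet been measured. It differs from compound 3 by bromo in place of chloro on an aromatic carbon, the same change already seen from compound 1 to compound 2, at the same place: on an aromatic carbon of a six-membered aromatic ring of carbon only, para to a large group.

For compound 4 in this assay a step of a 1.8-fold lower number from compound 3 to compound 4 (0.27 log units; within the scatter) is expected, set beside the earlier step of a 2.1-fold lower number from compound 1 to compound 2 (0.32 log units; beyond the scatter), because compound 3 starts from 240 nM on a core where this exchange has not yet been tested. The estimate for compound 4 is 130 nM, with a range of 60 nM to 300 nM expected.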

Compound 4, half-maximal effective concentration: 190 nM
The estimate for compound 4 lay 1.5-fold (0.16 log units) below the measured number; the measured number falls inside the stated range.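

In this assay, the exchange of 4-chlorophenyl for 4-bromophenyl on the core of compound 3 gives a 1.3-fold lower number from compound 3 to compound 4 (0.10 log units; within the scatter). Set beside the step on the core of compound 1, this result does not separate the two cores: the same change on two cores in this assay, a 2.1-fold lower number (0.32 log units; beyond the scatter) from compound 1 to compound 2 and a 1.3-fold lower number (0.10 log units; within the scatter) from compound 3 to compound 4, 1.6-fold (0.22 log units) apart, within the scatter of two such steps. The exchange therefore carries over without a detectable difference in step size across these two pairs, but on the core of compound 3 the step cannot be told from repeat scatter, so no real gain from bromo is shown there, and two pairs say nothing about a further core.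

Still open, on these data alone, is how other groups at this place on the aromatic ring would behave on either core, such as fluoro, iodo, methyl, methoxy or nitrile, or plain hydrogen in place of the halogen. Also open, as far as these compounds go, is whether the small size of the exchange would persist with a different group on the ether oxygen, such as a longer chain or one carrying an amine or a carboxylic acid.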